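This account rests on a few compounds, and the source may have more. Where it says the series, first, only, none or still open, it means among the compounds named here.

In a functional assay on HepG2 cells (Homo sapiens) for inhibition, read by MTT assay (on this read-out higher numbers stand for weaker inhibition of growth and lower numbers for stronger inhibition of growth), compound 2 `COc1ccc(C(=O)Nc2cccc(-c3cc(=O)c4c(OC)c(OC)c(OC)cc4o3)c2)cc1` gives 22200 nM, the higher of the two exact numbers in this small set. Its nearest neighbour is compound 3 `COc1cccc(C(=O)Nc2cccc(-c3cc(=O)c4c(OC)c(OC)c(OC)cc4o3)c2)c1`, at 7060 nM. As far as these compounds go, compound 1 `COC(=O)c1ccc(C(=O)Nc2cccc(-c3cc(=O)c4c(OC)c(OC)c(OC)cc4o3)c2)cc1` returned only a limit, > 100000 nM, so its true position is unknown.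

Compound 4 `COc1ccc(C(=O)Nc2cccc(-c3cc(=O)c4c(O)c(OC)c(OC)cc4o3)c2)cc1` keeps the structure of compound 2 with one small edit: hydrogen in place of methyl on an oxygen on an aromatic ring, or methoxy to hydroxy (hydrogen in place of methyl on an oxygen on an aromatic ring).

Going by the values given here, no measured step makes this change, so the evidence is only indirect. Moving the methoxy group gave a modest shift, a 3.1-fold lower number from compound 2 to compound 3 (0.50 log units; beyond the scatter). Replacing methoxycarbonyl with methoxy gave an at least 4.5-fold lower number from compound 1 to compound 2 (0.65 log units; beyond the scatter), and that size rests on a limit. A larger step, an at least 14-fold lower number from compound 1 to compound 3 (1.15 log units; beyond the scatter), also rests on that limit and changes the same part of the molecule. These steps show that this assay responds to edits elsewhere in the molecule, but they say nothing firm about this oxygen.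

A modest change is therefore the most reasonable expectation, with only a slight lean towards stronger growth inhibition and no firm direction. The expected change is a 1.6-fold lower number from compound 2 to compound 4 (0.20 log units; within the scatter), which is an uncertain estimate. Compound 4 is estimated at 14000 nM, with an expected range of 4000 nM to 60000 nM.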

Compound 4, concentration for 50% growth inhibition: > 100000 nM
Compound 4 gave a limit, no number; the forecaster's own chance of this, stated with the estimate: 15%; middle value at least 7.1-fold (0.85 log units) from the limit.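

In this assay, swapping the methyl on this oxygen for hydrogen, which turns methoxy into hydroxy, gives an at least 4.5-fold higher number from compound 2 to compound 4 (0.65 log units; beyond the scatter), so growth inhibition weakens rather than holding steady. Going by these compounds alone, all the earlier steps changed the group on the carbonyl carbon, so this is the first sign that the shared core also responds to an edit, and here the loss of a single heavy atom is enough to produce a step beyond the scatter. Compound 4 returned a limit and not an exact number, so the step gives only a minimum size and the full loss stays unknown: the limit of > 100000 nM in this assay, at which 2 of the 4 values shown sit.

The compounds shown have only methoxy and hydroxy at this oxygen, so they cannot tell whether other groups here, such as ethoxy or an amine in place of the oxygen group, would keep or lose growth inhibition. As far as these compounds go, it also remains open whether the same change at the other two methoxy groups of the core, or on the 3-methoxyphenyl amide of compound 3, would weaken growth inhibition in the same way.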